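The source may report more compounds than this note shows. Statements on the series, on what has been measured and on what is new or still open speak of the compounds shown alone.

Measured so far in an ADME assay on MCF7-DOX cells (Homo sapiens) for cytotoxicity, read by MTT assay, with a stated time of 48 h; on this read-out lower numbers stand for stronger inhibition and higher numbers for weaker inhibition:

Compound 1 `COc1cc(OC)c(C(=O)/C=C/c2ccc(N(C)C)cc2)c(O)c1CC=C(C)C`: in this assay compound 1 reaches only the assay limit, > 100000 nM.
Compound 2 `COc1cc(OC)c(C(=O)/C=C/c2cccc([N+](=O)[O-])c2)c(O)c1CC=C(C)C`: in this assay compound 2 gives 57000 nM.

Among the measured compounds shown here, compound 2 holds the only number measured; the remaining value is a limit, (the limit of > 100000 nM in this assay, at which 1 of the 2 values shown sits). For the measured compounds named here, the one measured step, an at least 1.7-fold lower number from compound 1 to compound 2 (0.24 log units; that floor lies within the scatter), is 3-nitrophenyl in place of 4-(dimethylamino)phenyl on a double-bonded chain carbon bound to a double-bonded chain carbon, and its floor lies within the scatter, so it gives no firm direction.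

Compound 3 `COc1cc(OC)c(C(=O)/C=C/c2cccc(N3CCN(C)CC3)c2)c(O)c1CC=C(C)C` differs from compound 2 by 4-methylpiperazin-1-yl in place of nitro on an aromatic carbon, on an aromatic carbon of a six-membered aromatic ring of carbon only, meta to a large group. Going by the values given here, the step from compound 1 to compound 2 is the only one touching the same ring, and it was too small to read as beyond the scatter; nothing measured speaks to an amine-bearing ring in that place. The expected step in this assay for compound 3 is therefore none beyond the scatter, a 1.1-fold higher number from compound 2 to compound 3 (0.02 log units; within the scatter). In this assay compound 3 is estimated at 60000 nM, within 20000 nM to 200000 nM.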

Compound 3, half-maximal inhibitory concentration: > 100000 nM
Compound 3 gave a limit, no number; the forecaster's own chance of this, stated with the estimate: 40%; at least 1.6-fold (0.22 log units) between middle value and limit.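

Replacing nitro with 4-methylpiperazin-1-yl on this aromatic carbon, meta to a large group, gives in this assay an at least 1.7-fold higher number from compound 2 to compound 3 (0.24 log units; that floor lies within the scatter), so this change, like the earlier one on the same ring, has no firm direction, and its full size cannot be read from a floor. The new information is that a group carrying a six-membered non-aromatic ring at this place also ends in a limit rather than a number, which adds to the pile-up at the top of the measurable range: the limit of > 100000 nM in this assay, at which 2 of the 3 values shown sit. Among the compounds shown here, compound 2 therefore remains the only compound with a number, and no step on this ring yet reads as beyond the scatter.

As far as these compounds go, whether a primary amine or a carboxylic acid at this same place would give a number clearly under the limit stays open, as does the true value of compound 3 past its limit. The shared core is constant across the compounds shown, so what a change there would do in this assay also remains unknown.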